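A new side chain on compound 1

A few compounds are considered here, and "the series" means these few. Any claim that something is new, unique, unknown or untested is made for them only; others in the source may bear on it.

Within the data shown here, in a functional assay on MOLT-4 cells (Homo sapiens) (on this read-out lower numbers stand for stronger inhibition and higher numbers for weaker inhibition), compound 1 (`Cc1ccc(/C=C/C(=O)Oc2ccc(/C=C3\CCCCC3=O)cc2)cc1`) gives 156000 nM as the highest of three numbers so far. Compound 2 (`O=C(/C=C/c1ccc(F)cc1)Oc1ccc(/C=C2\CCCCC2=O)cc1`) gives 26600 nM and compound 3 (`O=C(/C=C/c1ccc(Cl)c(Cl)c1)Oc1ccc(/C=C2\CCCCC2=O)cc1`) gives 47300 nM on the same read-out.

Compound 4 (`Cc1ccc(/C=C/C(=O)Oc2ccc(/C=C3\CCCC(CN(C)C)C3=O)cc2)cc1`) is still unmeasured. It carries (dimethylamino)methyl in place of hydrogen on a saturated ring carbon of compound 1 ((dimethylamino)methyl in place of hydrogen on a saturated ring carbon).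

Two measured changes start from compound 1: fluoro in place of methyl gave a 5.9-fold lower number from compound 1 to compound 2 (0.77 log units; beyond the scatter) and 3,4-dichlorophenyl in place of 4-methylphenyl gave a 3.3-fold lower number from compound 1 to compound 3 (0.52 log units; beyond the scatter) as modest steps. The gap of a 1.8-fold higher number from compound 2 to compound 3 (0.25 log units; within the scatter) stays within the scatter. Neither change touches the saturated ring carbon, so no measurement tests the new group directly, and the guess remains loose.

A modest step to a lower number is expected, since compound 1 has 156000 nM and both changes from it lowered the number. The expected step is a 5.2-fold lower number from compound 1 to compound 4 (0.72 log units; beyond the scatter) on this evidence. Compound 4 is estimated at 30000 nM in this assay, with an expected range from 4000 nM to 170000 nM overall.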

Compound 4, half-maximal inhibitory concentration: 3390 nM
The estimate for compound 4 lay 8.8-fold (0.95 log units) above the measured number; the whole stated range lies above it.
By their numbers in this assay, from the lowest: compound 4; then compounds 2 and 3 (each within the scatter of the next); then compound 1.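

In this assay the saturated ring carbon turns out to be a highly responsive place on the core of compound 1: (dimethylamino)methyl in place of hydrogen there gives a 46-fold lower number from compound 1 to compound 4 (1.66 log units; beyond the scatter) and ranks as a large step. The best earlier change, fluoro in place of methyl on an aromatic carbon, gave only a 5.9-fold lower number from compound 1 to compound 2 (0.77 log units; beyond the scatter) and so moved the number far less. Nothing available explains why this group has so large an effect.

The compounds shown leave open whether the nitrogen matters or whether any chain on this carbon would do, and a plain propyl chain or a morpholinylmethyl group at the same place would help separate the two. They also leave open whether the same step would hold on the core of compound 2.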